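Aryl ester variation on a shared terpenoid core

The compounds below may be only part of what the source reports. "The series", "measured", "known", "first", "only" and "open" are said of these compounds alone.

Measured compounds in a functional assay on PC-3 cells (Homo sapiens) for antiproliferative activity, read by sulforhodamine B assay, with a stated time of 48 h, tested at 50 uM; on this read-out lower numbers stand for less inhibition and higher numbers for more inhibition at the one concentration tested (going by the name of the read-out):
compound 1, `CC1=CC[C@H](C(C)C)c2cc(C)c(OC(=O)c3ccc([N+](=O)[O-])cc3)cc21`, gives 36.7%
compound 2, `CC1=CC[C@H](C(C)C)c2cc(C)c(OC(=O)c3cccc(C)c3)cc21`, gives 38.6%

Compound 2 shows the higher of the two numbers, with compound 1 nearest and the step of a number 1.9 percentage points higher from compound 1 to compound 2 (within the scatter) within the scatter; the two compounds are therefore not told apart by this read-out.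

Compound 3, `COc1ccc(C(=O)Oc2cc3c(cc2C)[C@@H](C(C)C)CC=C3C)cc1`, is not yet measured. It differs from compound 2 by the change (4-methoxyphenyl in place of 3-methylphenyl on a carbonyl carbon).

Within the data shown here, the only step that bears on this is the one on the same carbonyl carbon, a number 1.9 percentage points higher from compound 1 to compound 2 (within the scatter), which swapped 4-nitrophenyl for 3-methylphenyl without moving the number beyond the scatter. Among the measured compounds shown here, no measured step involves 4-methoxyphenyl. On that basis the expected step of a number 0.6 percentage points lower from compound 2 to compound 3 (within the scatter) is none beyond the scatter. Compound 3 is therefore estimated at 38% in this assay, with a range from 24% to 52%.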

Compound 3, a percentage reported as inhibition, at one concentration (the size of the read-out at that concentration, not a potency): 60.6%
Estimate against measurement, compound 3: 22.6 percentage points below, and the stated range ends below it.
By their numbers in this assay, from the lowest: compounds 1 and 2 (each within the scatter of the next); then compound 3.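

On the carbonyl carbon of the ester, the earlier pair left the aryl group looking interchangeable, but the number in this assay does respond to this group, as 4-methoxyphenyl in place of 3-methylphenyl gives a number 22 percentage points higher from compound 2 to compound 3 (beyond the scatter) in this series. Methoxy in place of nitro on an aromatic carbon gives a number 23.9 percentage points higher from compound 1 to compound 3 (beyond the scatter) and, with both steps beyond the scatter, compound 3 has the highest number of the three. Nothing measured here accounts for this rise.

Still open, on these data alone, is whether the methoxy group itself carries the rise, or whether a 4-hydroxyphenyl, 4-ethoxyphenyl or 4-aminophenyl group on the same carbonyl carbon would do the same. With one concentration only, these numbers also leave the potency of compound 3 unsettled.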